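The source may report more compounds than this note shows. Statements on the series, on what has been measured and on what is new or still open speak of the compounds shown alone.

Measured in a functional assay on HL-60 cells (Homo sapiens) for antiproliferative activity, read by MTT assay, with a stated time of 24 h; on this read-out lower numbers stand for stronger inhibition and higher numbers for weaker inhibition:
- Compound 1 `CCCCc1oc2ccccc2c1C(=O)c1ccc(OCC(=O)NC(C)C)cc1`: 360 nM
- Compound 2 `CCCCc1oc2ccccc2c1C(=O)c1ccc(OCC(=O)N2CCCCC2)cc1`: > 50000 nM (a limit of the assay)
- Compound 3 `CCCCc1oc2ccccc2c1C(=O)c1ccc(OCC(=O)N2CCOCC2)cc1`: > 50000 nM (a limit of the assay)

Compound 3 has no numerical value, and its > 50000 nM is a limit of the assay. It shares this position with compound 2, at the limit of > 50000 nM in this assay, at which 2 of the 3 values shown sit. The step to compound 4 `CCCCc1oc2ccccc2c1C(=O)c1ccc(OCC(=O)NCc2ccccc2)cc1` is benzylamino in place of morpholin-4-yl on a carbonyl carbon. In words, it places benzylamino in place of morpholin-4-yl on a carbonyl carbon.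

Among the measured compounds shown here, two measured steps bear on this change. One is an at least 130-fold higher number from compound 1 to compound 3 (2.14 log units; beyond the scatter), and the other is an at least 130-fold higher number from compound 1 to compound 2 (2.14 log units; beyond the scatter). Both are large and lie beyond the scatter. The third step, a step that the two limits leave unreadable from compound 2 to compound 3, offers no size to work with. Compound 4 keeps the amide hydrogen, as compound 1 does, and compound 1 alone gives a number, 360 nM. Read in reverse, the two large steps lead one to expect a large move toward lower numbers in this assay. However, benzylamino itself has not been measured, and three compounds are a thin basis, so the expected size is uncertain. The expected step is an at least 55-fold lower number from compound 3 to compound 4 (1.74 log units; beyond the scatter). Compound 4 is estimated at 900 nM, with an expected range from 150 nM to 8000 nM.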

Compound 4, half-maximal inhibitory concentration: > 50000 nM
Compound 4: a limit, no number (the forecaster's own chance of this, stated with the estimate: 15%); at least 55-fold (1.74 log units) between middle value and limit.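

In this assay compound 4 sits at a limit of the assay rather than at a number, so its steps from compound 2 and from compound 3 cannot be read. Compounds 2 and 3 both lack the amide hydrogen, which left open the possibility that keeping it would be enough to retain a measurable value; compound 4 keeps it and goes against that reading, with benzyl in place of isopropyl on the amide-type nitrogen giving an at least 130-fold higher number from compound 1 to compound 4 (2.14 log units; beyond the scatter). Among the four compounds, isopropylamino is therefore the only group on the carbonyl carbon that gives a number, and compound 1 stands alone: the limit of > 50000 nM in this assay, at which 3 of the 4 values shown sit.

The compounds shown leave open whether the activity depends narrowly on isopropyl, since ethyl, cyclopropyl or tert-butyl on the amide-type nitrogen would test how much change this position tolerates. They also leave open how a phenyl or a 2-phenylethyl group in the same place would read, and how far compounds 2, 3 and 4 differ from one another beyond the limit they share.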